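Working notes: chloro on the anilino ring of compound 1

This account rests on a few compounds, and the source may have more. Where it says the series, first, only, none or still open, it means among the compounds named here.

Measured in a functional assay on FM3A cells (Mus musculus) for antiproliferative activity, read by cell counting, with a stated time of 2 days; a higher number here means a weaker inhibitor, a lower number a stronger inhibitor:
- Compound 1 `COc1cc(C(=O)c2sc(Nc3ccccc3)nc2N)cc(OC)c1OC`: 23 nM
- Compound 2 `COc1ccc(C(=O)c2sc(Nc3ccccc3)nc2N)cc1OC`: > 10000 nM, a limit and not a number
- Compound 3 `COc1ccc(Nc2nc(N)c(C(=O)c3ccc(Br)cc3)s2)cc1`: 100 nM

Of the two exact values, compound 1 at 23 nM has the lower number, and the gap to compound 3 at 100 nM lies beyond the scatter. Compound 4 `COc1cc(C(=O)c2sc(Nc3ccc(Cl)cc3)nc2N)cc(OC)c1OC` differs from compound 1 by chloro in place of hydrogen on an aromatic carbon, so phenyl becomes 4-chlorophenyl. Within the data shown here, the only measured step, an at least 430-fold higher number from compound 1 to compound 2 (2.63 log units; beyond the scatter), is large but involves a methoxy group, not this place, so it bears only weakly. A small rise in this assay is therefore expected, perhaps within the scatter. The expected change is a 1.7-fold higher number from compound 1 to compound 4 (0.24 log units; within the scatter). For compound 4 the estimated value is 40 nM, with an expected range of 12 nM to 150 nM.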

Compound 4, half-maximal inhibitory concentration: 420 nM
Compound 4: middle estimate off by 11-fold (1.02 log units), on the low side; measured number above the stated range.
By their numbers in this assay, from the lowest: compound 1; then compound 3; then compound 4. At a limit, above all of these: compound 2.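

In this assay, the anilino ring of compound 1 is not a tolerant place for this change: chloro in place of hydrogen on an aromatic carbon gives an 18-fold higher number from compound 1 to compound 4 (1.26 log units; beyond the scatter) as the first step shown at this ring. The step is large and beyond the scatter, so phenyl to 4-chlorophenyl matters here. Nothing at hand bears on the reason for this step.

Only hydrogen and chloro can be compared at this place. Going by these compounds, whether chloro alone raises the number or any group there does stays open, and fluoro or methyl on the same carbon would separate the two.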